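The source may hold more compounds than are shown below. What is called first, only, known or untested is meant among the compounds shown, and "the series" means these compounds.

Measured so far in a functional assay on A2780 cells (Homo sapiens) for inhibition, read by sulforhodamine B assay, with a stated time of 72 h; a lower number here means a stronger inhibitor, a higher number a weaker inhibitor:
- Compound 1 `O=C(NCc1ccc(S(=O)(=O)c2ccccc2C(F)(F)F)cc1)c1cc2cnccc2[nH]1`: 25 nM
- Compound 2 `O=C(NCc1ccc(S(=O)(=O)c2ccccc2)cc1)c1cc2cnccc2[nH]1`: 18 nM

Compound 2 gives 18 nM and compound 1 gives 25 nM, so the two cannot be told apart in this assay. Compound 3 `O=C(NCc1ccc(S(=O)(=O)c2ccc(F)c(F)c2)cc1)c1cc2cnccc2[nH]1` keeps the rest of compound 2 and changes only the ring on the sulfonyl sulfur: 3,4-difluorophenyl in place of phenyl on a sulfonyl sulfur. Going by the values given here, one measured step bears on this, and only indirectly, since it also concerns a group on the aromatic ring attached to the sulfonyl sulfur: a 1.4-fold lower number from compound 1 to compound 2 (0.14 log units; within the scatter). Removing trifluoromethyl therefore made no difference that the measurements can resolve. Fluorine itself has not been tested in this series, so the comparison is loose, and no step beyond the scatter is expected. The estimated change is no change at the digits printed from compound 2 to compound 3 (within the scatter). For compound 3 the expected value is 18 nM, within an estimated range of 7 nM to 45 nM.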

Compound 3, half-maximal inhibitory concentration: 14 nM
For compound 3 the middle estimate is 1.3-fold (0.11 log units) above the measured one, and the stated range covers the measured number.
By their numbers in this assay, from the lowest: compounds 3, 2 and 1 (each within the scatter of the next).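

In this assay placing 3,4-difluorophenyl on the sulfonyl sulfur in place of phenyl gives a 1.3-fold lower number from compound 2 to compound 3 (0.11 log units; within the scatter) and placing it there in place of 2-(trifluoromethyl)phenyl gives a 1.8-fold lower number from compound 1 to compound 3 (0.25 log units; within the scatter) so neither step can be resolved from the usual scatter. Going by these compounds alone, this position has now carried three different aromatic carbon rings, fluorine among their substituents for the first time, and the assay separates none of the three compounds from the others. Nothing measured here accounts for this result.

Going by these compounds, all three compounds keep a six-membered aromatic ring of carbon on the sulfonyl sulfur, so the effect of a saturated ring such as cyclohexyl, or of a ring bearing an amine or a carboxylic acid, remains open. On these data alone, it is also open whether any substituent on this ring can shift the number beyond the scatter.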